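Swapping a (tert-butoxy)methyl for a methanesulfonamido group

This account rests on a few compounds, and the source may have more. Where it says the series, first, only, none or still open, it means among the compounds named here.

Of the compounds shown here, three sharing one core have been measured in a functional assay for agonist activity at G protein-coupled receptor 88 (Homo sapiens), read by HTRF and cAMP accumulation; a lower number here means that less compound is needed, a higher number that more compound is needed for the effect. Compound 1 `CC[C@H](C)[C@H](N)CN(C(=O)[C@@H]1C[C@H]1c1ccccc1)c1ccc(-c2ccc(OC(C)C)cc2)cc1` gives 72 nM. Compound 2 `CC[C@H](C)[C@H](N)CN(C(=O)[C@@H]1C[C@H]1c1ccccc1)c1ccc(-c2ccc(COC)cc2)cc1` gives 35 nM, and compound 3 `CC[C@H](C)[C@H](N)CN(C(=O)[C@@H]1C[C@H]1c1ccccc1)c1ccc(-c2ccc(COC(C)(C)C)cc2)cc1` gives 280 nM, the highest of the three numbers. The steps among them are modest: a 2.1-fold lower number from compound 1 to compound 2 (0.31 log units; beyond the scatter), a 3.9-fold higher number from compound 1 to compound 3 (0.59 log units; beyond the scatter), and an 8.0-fold higher number from compound 2 to compound 3 (0.90 log units; beyond the scatter).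

Compound 4 `CC[C@H](C)[C@H](N)CN(C(=O)[C@@H]1C[C@H]1c1ccccc1)c1ccc(-c2ccc(NS(C)(=O)=O)cc2)cc1` is not yet measured. Relative to compound 3 the change is methanesulfonamido in place of (tert-butoxy)methyl on an aromatic carbon. Among the measured compounds shown here, no measured step covers this exact exchange. The step that bears on it most is the one in which tert-butyl replaces methyl on the oxygen, where compound 2 and compound 3 differ, an 8.0-fold higher number from compound 2 to compound 3 (0.90 log units; beyond the scatter), and the step from isopropoxy to (tert-butoxy)methyl, a 3.9-fold higher number from compound 1 to compound 3 (0.59 log units; beyond the scatter), both of which left compound 3 with the highest number. Compound 4 carries the smaller substituent at the same place, so the number in this assay is expected to move downward, by a step of about a 3.1-fold lower number from compound 3 to compound 4 (0.49 log units; beyond the scatter), though with wide uncertainty since the entering group differs in kind from anything measured. Compound 4 is therefore estimated at 90 nM, in the range 20 nM to 450 nM.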

Compound 4, half-maximal effective concentration: 1200 nM
Beside the measured number, compound 4's estimate is 13-fold (1.12 log units) below it, and the stated range ends below it.
By their numbers in this assay, from the lowest: compound 2; then compound 1; then compound 3; then compound 4.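

In this assay the methanesulfonamido group on this aromatic carbon, para to a large group, gives the highest number of the four compounds, with steps against all three ether-bearing compounds (first a 4.3-fold higher number from compound 3 to compound 4 (0.63 log units; beyond the scatter), then a 17-fold higher number from compound 1 to compound 4 (1.22 log units; beyond the scatter), and largest a 34-fold higher number from compound 2 to compound 4 (1.54 log units; beyond the scatter)). Among compounds 1, 2 and 3 the highest number went with the largest ether group, but compound 4 goes against that pattern: its entering group has 5 heavy atoms against 6 in the (tert-butoxy)methyl that leaves, yet its number is higher still. The change also brings in a sulfur, a nitrogen and a hydrogen-bond donor together, and nothing available here ties the rise to any one of these features.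

The compounds shown leave open whether the loss follows the hydrogen-bond donor or the sulfonyl unit, a question that an N-methyl methanesulfonamido, an acetamido or a methylsulfonyl group at this place would bear on. They also leave open whether the rise extends to other groups carrying a donor, such as a hydroxymethyl, an amine or a carboxylic acid.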